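Acid-to-amide swap on the side chain, compound 4

The source may report more compounds than this note shows. Statements on the series, on what has been measured and on what is new or still open speak of the compounds shown alone.

Measured so far:
compound 1 `C[C@H](NC(=O)CN(c1nc(Cl)nc2[nH]cnc12)C1CC1)C(=O)O` gives 48.1%
compound 2 `O=C(O)CC[C@H](NC(=O)CN(c1nc(Cl)nc2[nH]cnc12)C1CC1)C(=O)O` gives 26.8%
compound 3 `O=C(O)C[C@H](NC(=O)CN(c1nc(Cl)nc2[nH]cnc12)C1CC1)C(=O)O` gives 19.9%

All three numbers come from a functional assay on the whole organism (Tail, strain ICR) with Mus musculus as the target, in the tail flick test, with a stated time of 30 min, at a dose of 25 umol/kg by the oral route; on this read-out higher numbers stand for a stronger effect at the one dose given and lower numbers for a weaker effect. Compound 3 stands lowest of the three, but compound 2 lies within the scatter of it, so only compound 1 is clearly separated: a number 28.2 percentage points lower from compound 1 to compound 3 (beyond the scatter). The parallel step a number 21.3 percentage points lower from compound 1 to compound 2 (beyond the scatter) is of similar size, while a number 6.9 percentage points lower from compound 2 to compound 3 (within the scatter) is too small to read.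

Compound 4 `NC(=O)CC[C@H](NC(=O)CN(c1nc(Cl)nc2[nH]cnc12)C1CC1)C(=O)O` differs from compound 3 by carbamoylmethyl in place of carboxy on a saturated chain carbon, two bonds along the chain from an amide-type nitrogen and a carbonyl carbon. Within the data shown here, no measured pair shows a carboxy group exchanged for a carbamoyl group, so the only guide is that compound 2 and compound 3, which carry carboxymethyl and carboxy at this position, sit close together and both well below compound 1. Compound 4 is therefore expected to stay near that lower pair, with the step of a number 7.1 percentage points higher from compound 3 to compound 4 (within the scatter) anticipated to fall within the scatter. The estimate for compound 4 is 27%, with a range from 14% to 44%.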

Compound 4, a percentage reported as activity, at one dose (the size of the read-out at that dose, not a potency): 33.1%
Compound 4: the middle estimate sits 6.1 percentage points below what was measured, and the stated range covers the measured number.
By their numbers in this assay, from the lowest: compounds 3, 2 and 4 (each within the scatter of the next, the first and the last beyond it); then compound 1.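

Amino in place of hydroxy on a carbonyl carbon, the one direct acid-to-amide exchange in the set, gives in this assay a number 6.3 percentage points higher from compound 2 to compound 4 (within the scatter), so this exchange on its own cannot be read. Carbamoylmethyl in place of carboxy gives a number 13.2 percentage points higher from compound 3 to compound 4 (beyond the scatter), the only separation so far among the groups larger than the methyl of compound 1, but this step alters both the chain length and the end group, and the two cannot be told apart here. Carbamoylmethyl in place of hydrogen still gives a number 15 percentage points lower from compound 1 to compound 4 (beyond the scatter), so the lower numbers at this place are not confined to side chains ending in a carboxylic acid.

No measurement offers an explanation for any of these steps. Still open, on these data alone, is how a side chain ending in an amine, or a longer chain ending in a carbamoyl group, would read at this place.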